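Removing the Chloro Group from a Thioether Acylguanidine

This account rests on a few compounds, and the source may have more. Where it says the series, first, only, none or still open, it means among the compounds named here.

Compound 2 `Cc1cc(Sc2cccc(Cl)c2)c(S(C)(=O)=O)cc1C(=O)N=C(N)N` gives 37 nM in a functional assay for inhibition of sodium/hydrogen exchanger (Oryctolagus cuniculus) (a higher number here means a weaker inhibitor, a lower number a stronger inhibitor), and compound 1 `Cc1cc(C2CCCCC2)c(S(C)(=O)=O)cc1C(=O)N=C(N)N` gives 22 nM, so the two numbers sit within the scatter of each other, as the step of a 1.7-fold higher number from compound 1 to compound 2 (0.23 log units; within the scatter) confirms. Compound 3 `Cc1cc(Sc2ccccc2)c(S(C)(=O)=O)cc1C(=O)N=C(N)N` differs from compound 2 by hydrogen in place of chloro on an aromatic carbon. Within the data shown here, no measured pair tests this change directly; the single available step exchanges a whole group and is itself within the scatter, so compound 3 is expected to show no step beyond the scatter, a 1.1-fold higher number from compound 2 to compound 3 (0.03 log units; within the scatter). Compound 3 is therefore estimated at 40 nM, within a range from 15 nM to 110 nM.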

Compound 3, half-maximal inhibitory concentration: 14 nM
Compound 3: middle estimate off by 2.9-fold (0.46 log units), on the high side; the whole stated range lies above it.
By their numbers in this assay, from the lowest: compounds 3, 1 and 2 (each within the scatter of the next, the first and the last beyond it).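

Replacing the chloro with hydrogen gives a 2.6-fold lower number from compound 2 to compound 3 (0.42 log units; beyond the scatter) in this assay, so the chloro on this aromatic carbon is not needed for inhibition, and the phenylsulfanyl group serves better here than the (3-chlorophenyl)sulfanyl group. Set against cyclohexyl, the phenylsulfanyl group gives a 1.6-fold lower number from compound 1 to compound 3 (0.20 log units; within the scatter), so these two groups cannot be told apart in this assay. Nothing available explains why losing the chloro strengthens inhibition. Going by these compounds, it remains open whether a fluoro, a methoxy or an amine on this aromatic carbon would match hydrogen or fall back towards chloro.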